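Swapping a Trifluoromethyl for a Methyl on the Ether Oxygen

The compounds below may be only part of what the source reports. "The series", "measured", "known", "first", "only" and "open" are said of these compounds alone.

Of the compounds shown here, three built on one shared core have been tested in a functional assay on MCF7 cells (Homo sapiens) for inhibition, read by sulforhodamine B assay, with a stated time of 72 h; on this read-out lower numbers stand for stronger inhibition and higher numbers for weaker inhibition. Compound 1 `Cc1ccc(C2=Nn3c(nnc3C(C)c3ccc(CC(C)C)cc3)SC2)cc1` gives 6300 nM. Compound 2 `CC(c1ccc(-c2ccccc2)c(F)c1)c1nnc2n1N=C(c1ccc(OC(F)(F)F)cc1)CS2` gives 4800 nM. Within the data shown here, of the two numbers in hand, the one for compound 2 is the lower, yet its gap to compound 1 lies within the usual scatter of this assay, so the two cannot be told apart on these data. Compound 3 `CC(c1ccc(-c2ccccc2)c(F)c1)c1n[nH]c(=S)n1N`, which lacks the larger ring system of the other two, is reported in this assay only as "not active" (no number reported), without a number.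

Compound 4 `COc1ccc(C2=Nn3c(nnc3C(C)c3ccc(-c4ccccc4)c(F)c3)SC2)cc1` has not yet been measured. It differs from compound 2 in one place: methyl in place of trifluoromethyl on an oxygen on an aromatic ring. Among the measured compounds shown here, no measured pair in this set shows what such a swap does, so there is no direct guide. Since the change is small and sits at the outer edge of the molecule, the step from compound 2 to compound 4 is expected to be small, with no clear direction beyond the scatter, and is estimated as a 1.1-fold higher number from compound 2 to compound 4 (0.06 log units; within the scatter). Compound 4 is therefore expected to give about 5500 nM in this assay, with a plausible range from 2000 nM to 15000 nM.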

Compound 4, half-maximal inhibitory concentration: 2600 nM
Compound 4: the middle estimate sits 2.1-fold (0.33 log units) above what was measured, within the range that was stated.
By their numbers in this assay, from the lowest: compounds 4, 2 and 1 (each within the scatter of the next, the first and the last beyond it).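

Among these compounds, this is the first measured pair for this swap: in this assay, methyl in place of trifluoromethyl on the ether oxygen gives a 1.8-fold lower number from compound 2 to compound 4 (0.27 log units; within the scatter) and so stays within the usual scatter of repeated measurements. At this outer position, then, the three fluorine atoms can go without any change that this assay can distinguish from noise, and compound 4 still gives a real number rather than a report of no activity. Nothing in hand accounts for how the two compounds compare, and a single pair within the scatter offers no trend to interpret.

The compounds shown do not reveal whether the position accepts groups that differ more from these two, such as a longer chain on the oxygen like ethyl or butyl, a free hydroxyl, or an amine or a carboxylic acid on the aromatic ring in place of the ether. Among the compounds shown here, with only this one pair, it also remains open whether the same swap would behave in the same way when the rest of the molecule is different.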